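Methoxy to hydroxy on a shared pyrazole-bearing urea series

A few compounds are considered here, and "the series" means these few. Any claim that something is new, unique, unknown or untested is made for them only; others in the source may bear on it.

Working notes. Compound 3 `COc1cc(-c2nn(-c3cccc(NC(=O)Nc4ccc(Cl)c(Cl)c4)c3)cc2-c2ccncc2)ccc1Cl` carries a methoxy group on the chlorophenyl ring and a (3,4-dichlorophenyl)amino urea. In a functional assay on IGROV-1 cells (Homo sapiens) for inhibition, read by sulforhodamine B assay, with a stated time of 48 h (a lower number here means that less compound is tolerated, a higher number that more compound is tolerated), compound 3 gives only the limit > 50000 nM, not a number. Its nearest measured neighbour, compound 2 `COc1cc(-c2nn(-c3cccc(NC(=O)c4cccc(C(F)(F)F)c4)c3)cc2-c2ccncc2)ccc1Cl`, differs in the urea-to-amide part; in this assay compound 2 also stops at the limit > 50000 nM. Among the compounds with values here, the one measured step, a step that the two limits leave unreadable from compound 2 to compound 3, is therefore unreadable and concerns a different position than the change now followed. Compound 1 `O=C(Nc1cccc(-n2cc(-c3ccncc3)c(-c3ccc(Cl)c(O)c3)n2)c1)Nc1cccc(C(F)(F)F)c1` already carries the hydroxy group with a 3-(trifluoromethyl)phenyl urea, and in this assay compound 1 reaches only the limit > 32500 nM. The step to compound 4 `O=C(Nc1cccc(-n2cc(-c3ccncc3)c(-c3ccc(Cl)c(O)c3)n2)c1)Nc1ccc(Cl)c(Cl)c1` is hydrogen in place of methyl on an oxygen on an aromatic ring. Within the data shown here, both the limit of > 32500 nM in this assay, at which 1 of the 3 values shown sits, and the limit of > 50000 nM in this assay, at which 2 of the 3 values shown sit, show that every value so far is a limit, so no direction can be read. The step from compound 3 to compound 4 is expected to be a number no higher from compound 3 to compound 4 (the limit leaves the size open), that is none beyond the scatter. Compound 4 is expected to give about 50000 nM, range 20000 nM to 120000 nM, most likely again a limit.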

Compound 4, concentration lethal to 50% of the cells: > 32500 nM
Compound 4 gave a limit, no number (the forecaster's own chance of this, stated with the estimate: 85%); the middle value lies beyond the limit too.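

In this assay compound 4 gives > 32500 nM, a limit and not a number. Its steps from compound 3 and from compound 1 join limits only, so neither can be read. The compounds shown leave open whether methoxy to hydroxy changes this read-out at all.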